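The source may report more compounds than this note shows. Statements on the series, on what has been measured and on what is new or still open speak of the compounds shown alone.

Of the compounds shown here, two with a shared core have been measured for cytotoxicity, and they differ in the aryl group on the amide nitrogen. Compound 1, `CC(C)n1ccc2c(C(=O)Nc3ccc(F)cc3)cc(-c3cccs3)nc21`, carries a fluorophenyl group there. In an ADME assay on LLC-MK2 cells (Macaca mulatta) for cytotoxicity, read by spectrophotometry and crystal violet staining, with a stated time of 4 days (a lower number here means that less compound is tolerated, a higher number that more compound is tolerated), compound 1 reports no number but only a limit, > 200000 nM. Compound 1 thus sits at the limit of > 200000 nM in this assay, at which 1 of the 2 values shown sits. Compound 2, `CC(C)n1ncc2c(C(=O)Nc3ccncc3)cc(-c3cccs3)nc21`, carries a pyridin-4-yl group on the amide nitrogen. In this assay compound 2 gives 6300 nM, which is the only number shown among the two values, so compound 2 is the sole anchor for any estimate. For the measured compounds named here, no step between two measured compounds is known here, and none bears on the change that follows.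

Compound 3, `CC(C)n1ncc2c(C(=O)Nc3cncnc3)cc(-c3cccs3)nc21`, has not been measured. It differs from compound 2 by pyrimidin-5-yl in place of pyridin-4-yl on an amide-type nitrogen. Nothing measured speaks to the effect of this exchange on cytotoxicity, so the expectation rests on compound 2 alone. The step from compound 2 to compound 3 is expected to be a 1.3-fold higher number from compound 2 to compound 3 (0.10 log units; within the scatter), which is no step beyond the usual scatter. Compound 3 is therefore expected to give about 8000 nM in this assay, with a likely range from 3000 nM to 25000 nM.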

Compound 3, half-maximal cytotoxic concentration: 20000 nM
The estimate for compound 3 lay 2.5-fold (0.40 log units) below the measured number; measured number inside the range.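

In this assay, for the compounds shown here, the first step that can be read at this position is a 3.2-fold higher number from compound 2 to compound 3 (0.50 log units; beyond the scatter), and it comes with pyrimidin-5-yl in place of pyridin-4-yl on the amide-type nitrogen. The two groups have the same number of heavy atoms and each is one six-membered aromatic ring, yet exchanging one ring carbon for a nitrogen moves the number beyond the usual scatter, which compound 2 alone could not show. No measurement shown here accounts for this step.

Going by these compounds alone, compound 1 gives only a limit and differs from compound 2 in more than one place, so no step involving compound 1 can be read. From the compounds shown here alone, it remains open whether the higher number at this position would persist with other groups on the amide-type nitrogen, such as a piperidine ring, a benzoic acid or a simple phenyl ring, and whether the same exchange would give a similar step on a different core.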